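The source may hold more compounds than are shown below. What is called first, only, known or untested is meant among the compounds shown, and "the series" means these compounds.

Compounds measured in an ADME assay for pharmacokinetics, read by HPLC, in phosphate buffer, with a stated time of 72 h, at pH 7.4, tested at 250 uM; on this read-out higher numbers stand for a longer-lived compound and lower numbers for a shorter-lived compound:
Compound 1, `C=CC(=O)Nc1cc(C(F)(F)F)cc(C(F)(F)F)c1`: compound 1 gives 5.3 h.
Compound 2, `C=CS(=O)(=O)c1cc(C(F)(F)F)cc(C(F)(F)F)c1`: compound 2 gives < 0.017 h, a limit of the assay.
Compound 3, `N#Cc1cc(C(F)(F)F)cc(C(F)(F)F)c1`: compound 3 gives > 50 h, also a limit of the assay.

Compound 3 thus stands at the upper edge of what this assay reports (the limit of > 50 h in this assay, at which 1 of the 3 values shown sits), while compound 2 sits at the lower edge (the limit of < 0.017 h in this assay, at which 1 of the 3 values shown sits). Both steps into compound 3 point upward: an at least 9.4-fold higher number from compound 1 to compound 3 (0.97 log units; beyond the scatter), and an at least 2900-fold higher number from compound 2 to compound 3 (3.46 log units; beyond the scatter). Compound 4, `FC(F)(F)c1cc(S)cc(C(F)(F)F)c1`, differs from compound 3 in one place: sulfanyl in place of cyano on an aromatic carbon. Going by the values given here, no measured step exchanges a cyano for a sulfanyl, so the measured steps only frame how far this shared core has moved on either side. For compound 4 the estimate is 20 h, with a range from 3 h to 50 h, which is an expected step of an at least 2.5-fold lower number from compound 3 to compound 4 (0.39 log units; beyond the scatter) in this assay.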

Compound 4, half-life: > 50 h
Compound 4 was reported as a limit; the forecaster's own chance of this, stated with the estimate: 30%; middle value at least 2.5-fold (0.39 log units) away from the limit.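

In this assay, going by these compounds alone, the value of compound 4 is a limit, which shows that cyano is not the only group on this aromatic carbon to reach the upper edge: the limit of > 50 h in this assay, at which 2 of the 4 values shown sit. Sulfanyl in this place also stands clear of the two vinyl-bearing groups, with an at least 2900-fold higher number from compound 2 to compound 4 (3.46 log units; beyond the scatter) and an at least 9.4-fold higher number from compound 1 to compound 4 (0.97 log units; beyond the scatter). The step between compound 3 and compound 4 cannot be read: both values are limits. From the compounds shown here alone, how far apart these two lie remains open, as does whether an amine or a carboxylic acid in this place would also reach that limit.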